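The source may report more compounds than this note shows. Statements on the series, on what has been measured and on what is new or still open speak of the compounds shown alone.

The compounds measured so far:
compound 1, `Cc1oc(=O)oc1COC(=O)N1C[C@@H]2C[C@H]1C(=O)Nc1cccc(c1)C(=O)OCc1oc(=O)oc1COC(=O)C1=C(S2)[C@H](C)[C@@H]2[C@@H]([C@@H](C)O)C(=O)N12`: > 95%
compound 2, `C[C@@H](O)[C@H]1C(=O)N2C3=C(S[C@@H]4CN[C@@H](C4)C(=O)Nc4cccc(c4)C(=O)OC/C=C\COC3=O)[C@H](C)[C@H]12`: > 95%
compound 3, `Cc1oc(=O)oc1COC(=O)N1C[C@@H]2C[C@H]1C(=O)Nc1cccc(c1)C(=O)OC/C=C\COC(=O)C1=C(S2)[C@H](C)[C@@H]2[C@@H]([C@@H](C)O)C(=O)N12`: > 95%

In an ADME assay for metabolic stability, read by LC-MS, with a stated time of 3 h, at pH 6.5, tested at 50 uM (on this read-out lower numbers stand for a less stable compound and higher numbers for a more stable compound), compound 1 gives a value that is a limit of the assay, > 95%. Compound 2 also sits at a limit, > 95%. Compound 3 sits at a limit too, > 95%. All three values thus share (the limit of > 95% in this assay, at which 3 of the 3 values shown sit), and no number is known for any of them.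

The change from compound 3 to compound 2 is a hydrogen atom in place of a group of 11 heavy atoms (6 carbon, 5 oxygen; one five-membered aromatic ring with 2 hetero atoms), on an amine nitrogen in a ring. Its size is a step that the two limits leave unreadable from compound 3 to compound 2. The same kind of change leads from compound 1 to compound 4, `C[C@@H](O)[C@H]1C(=O)N2C3=C(S[C@@H]4CN[C@@H](C4)C(=O)Nc4cccc(c4)C(=O)OCc4oc(=O)oc4COC3=O)[C@H](C)[C@H]12`, namely (a hydrogen atom in place of a group of 11 heavy atoms (6 carbon, 5 oxygen; one five-membered aromatic ring with 2 hetero atoms), on an amine nitrogen in a ring). The place differs only in that the ring carrying the amine nitrogen in compound 1 is part of a fused or bridged system of six rings, whereas in compound 3 it belongs to a system of five rings. How the cores of compound 1 and compound 3 differ is not broken down here.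

Because the limit of > 95% in this assay, at which 3 of the 3 values shown sit, holds for every measured value, the step from compound 1 to compound 4 is expected to be a step that the limit leaves unreadable from compound 1 to compound 4, and compound 4 is most likely to be reported as a limit as well. Compound 4 is expected to give about 97%, estimated to lie between 90% and 100%.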

Compound 4, percent of the compound remaining: > 95%
Compound 4 ended at the assay's limit (the forecaster's own chance of this, stated with the estimate: 80%); the middle value is on the limit's open side.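

In this assay compound 4 gives > 95% which is a limit of the assay and not a number, so the change from compound 1 to compound 4 yields no readable step. The compounds shown leave open whether any of them differs from another in stability, because all of them share one limit: the limit of > 95% in this assay, at which 4 of the 4 values shown sit.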